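Capping the hydroxy of compound 3 with methoxymethyl

The compounds below may be only part of what the source reports. "The series", "measured", "known", "first", "only" and "open" are said of these compounds alone.

Measured in a functional assay on RAW264.7 cells (Mus musculus) for inhibition, read by Griess assay, with stated times of 1 h and 24 h; a lower number here means a stronger inhibitor, a higher number a weaker inhibitor:
- compound 1 `O=C1CC(c2ccccc2OCc2ccc(F)cc2)Oc2ccccc21`: 28200 nM
- compound 2 `CCCOc1ccccc1C1CC(=O)c2ccccc2O1`: 46000 nM
- compound 3 `O=C1CC(c2ccccc2O)Oc2ccccc21`: 71300 nM

Compound 3 stands at 71300 nM, the top number of the three, though the nearest measured neighbour shows a 1.6-fold higher number from compound 2 to compound 3 (0.19 log units; within the scatter) and only the furthest shows a 2.5-fold higher number from compound 1 to compound 3 (0.40 log units; beyond the scatter).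

Compound 4 `COCOc1ccccc1C1CC(=O)c2ccccc2O1` has methoxymethyl in place of hydrogen on an oxygen on an aromatic ring.

Going by the values given here, two measured steps bear on this change, both involving the same oxygen and both read here in reverse. Removing propyl gave a 1.6-fold higher number from compound 2 to compound 3 (0.19 log units; within the scatter), and removing 4-fluorobenzyl gave a 2.5-fold higher number from compound 1 to compound 3 (0.40 log units; beyond the scatter). Methoxymethyl has no ring, so it is compared more closely with propyl, and only a small shift towards a lower number in this assay is anticipated, not one clearly beyond the scatter.

The expected change is a 1.4-fold lower number from compound 3 to compound 4 (0.15 log units; within the scatter).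

For compound 4 the estimated value is 50000 nM, with an expected range of 25000 nM to 100000 nM.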

Compound 4, half-maximal inhibitory concentration: 32600 nM
Compound 4: the middle estimate sits 1.5-fold (0.19 log units) above what was measured; the range from low to high includes it.
By their numbers in this assay, from the lowest: compounds 1, 4, 2 and 3 (each within the scatter of the next, the first and the last beyond it).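

In this assay, capping the hydroxy with methoxymethyl gives a 2.2-fold lower number from compound 3 to compound 4 (0.34 log units; beyond the scatter) and so clears the scatter with a group that has no ring, which until now only 4-fluorobenzyl had done at this oxygen. Among the capped compounds the readings stay together, with a 1.4-fold lower number from compound 2 to compound 4 (0.15 log units; within the scatter) and a 1.2-fold higher number from compound 1 to compound 4 (0.06 log units; within the scatter), so neither methoxy in place of ethyl nor methoxy in place of 4-fluorophenyl on the chain carbon gives a readable difference. No measurement at hand explains the effect of capping this oxygen.

Still open, on these data alone, is whether the chain oxygen of methoxymethyl contributes anything, or whether capping the hydroxy is enough on its own. A plain methyl, a longer chain such as 2-methoxyethyl, an amine such as 2-aminoethyl or a carboxylic acid on this oxygen would test how far the capped compounds' shared range extends.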